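Replacing the 2-methylphenyl amide group of compound 1

A few compounds are considered here, and "the series" means these few. Any claim that something is new, unique, unknown or untested is made for them only; others in the source may bear on it.

Of the compounds shown here, three built on one shared core have been tested in a functional assay on MCF7 cells (Homo sapiens) for antiproliferative activity, read by CCK-8 assay, with a stated time of 72 h; on this read-out higher numbers stand for weaker inhibition and lower numbers for stronger inhibition. Compound 1 `Cc1ccccc1C(=O)Nc1cccc(-c2oc3cc(-c4ccc(F)cc4)ccc3c(=O)c2O)c1` gives 2280 nM, the lowest of the three numbers. Compound 2 `O=C(Nc1cccc(-c2oc3cc(-c4ccc(F)cc4)ccc3c(=O)c2O)c1)c1ccc(Br)cc1` gives 24000 nM, and compound 3 `COc1ccc(C(=O)Nc2cccc(-c3oc4cc(-c5ccc(F)cc5)ccc4c(=O)c3O)c2)c(F)c1` gives 20000 nM. Each of the two changes away from compound 1 weakened inhibition clearly: an 11-fold higher number from compound 1 to compound 2 (1.02 log units; beyond the scatter) and an 8.8-fold higher number from compound 1 to compound 3 (0.94 log units; beyond the scatter). Between the other two compounds the gap is small, a 1.2-fold lower number from compound 2 to compound 3 (0.08 log units; within the scatter), so compound 2 and compound 3 cannot be told apart in this assay.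

Compound 4 `O=C(Nc1cccc(-c2oc3cc(-c4ccc(F)cc4)ccc3c(=O)c2O)c1)c1cc(F)cc(F)c1` has not yet been measured. It differs from compound 1 in one place: 3,5-difluorophenyl in place of 2-methylphenyl on a carbonyl carbon. Both measured replacements of 2-methylphenyl on this carbonyl carbon, by 4-bromophenyl and by 2-fluoro-4-methoxyphenyl, raised the number well beyond the scatter, and 3,5-difluorophenyl is a third such replacement. A step of similar size and in the same weakening direction is therefore expected for compound 4: a 6.6-fold higher number from compound 1 to compound 4 (0.82 log units; beyond the scatter). The estimate for compound 4 in this assay is 15000 nM, with a range from 4000 nM to 50000 nM.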

Compound 4, half-maximal inhibitory concentration: 2490 nM
Beside the measured number, compound 4's estimate is 6.0-fold (0.78 log units) above it; the measured number lies below the stated range.
By their numbers in this assay, from the lowest: compounds 1 and 4 (each within the scatter of the next); then compounds 3 and 2 (each within the scatter of the next).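

In this assay, changing this group need not weaken inhibition: a 1.1-fold higher number from compound 1 to compound 4 (0.04 log units; within the scatter), so the 2-methylphenyl and 3,5-difluorophenyl compounds cannot be told apart, and a methyl group on this ring is not required to reach the lower numbers. The choice of ring substituents on this carbonyl carbon still matters, as compound 4 separates clearly from both weaker compounds: an 8.0-fold lower number from compound 3 to compound 4 (0.90 log units; beyond the scatter) and a 9.6-fold lower number from compound 2 to compound 4 (0.98 log units; beyond the scatter). No measurement at hand explains why these substituted rings divide into two groups.

The compounds shown leave open how an unsubstituted phenyl group would compare with these substituted rings. They also leave open whether the aromatic ring can give way to a cyclohexyl group, a short alkyl chain or a chain ending in an amine.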